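The source may hold more compounds than are shown below. What is called first, only, known or untested is meant among the compounds shown, and "the series" means these compounds.

In an ADME assay on NIH3T3 cells (Mus musculus) for cytotoxicity (a lower number here means that less compound is needed, a higher number that more compound is needed for the effect), compound 1 (`Cc1ccccc1Oc1cccc(Cn2ccnc2)c1`) gives 79300 nM, compound 2 (`Cc1cc(Oc2cccc(Cn3cncn3)c2)cc(C)c1Cl`) gives 75900 nM and compound 3 (`Cc1cc(Oc2cccc(Cn3cnc4ccccc43)c2)cc(C)c1Cl`) gives 40000 nM. Compound 2 thus lies within the scatter of both compound 1 and compound 3. Compound 4 (`Cc1nnc(-c2cccc(Oc3cc(C)c(Cl)c(C)c3)c2)s1`) differs from compound 2 at one place: 5-methyl-1,3,4-thiadiazol-2-yl in place of (1H-1,2,4-triazol-1-yl)methyl on an aromatic carbon. There, 5-methyl-1,3,4-thiadiazol-2-yl stands in place of (1H-1,2,4-triazol-1-yl)methyl on an aromatic carbon. Going by the values given here, no measured pair shows this change on its own, so the expectation rests on those three values alone, and no step beyond the scatter is expected in this assay. The expected step is a 1.5-fold lower number from compound 2 to compound 4 (0.18 log units; within the scatter), which stays within the scatter. For compound 4 the estimated value is 50000 nM, with an expected range of 20000 nM to 100000 nM.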

Compound 4, half-maximal effective concentration: > 100000 nM
Compound 4 ended at the assay's limit; the forecaster's own chance of this, stated with the estimate: 15%; at least 2.0-fold (0.30 log units) between middle value and limit.
By their numbers in this assay, from the lowest: compounds 3, 2 and 1 (each within the scatter of the next). At a limit, above all of these: compound 4.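

In this assay compound 4 gives > 100000 nM as a limit of the assay and not a number: the limit of > 100000 nM in this assay, at which 1 of the 4 values shown sits.
Going by these compounds alone, the first single-place comparison at this position gives an at least 1.3-fold higher number from compound 2 to compound 4 (0.11 log units; that floor lies within the scatter) and so shows that 5-methyl-1,3,4-thiadiazol-2-yl in place of (1H-1,2,4-triazol-1-yl)methyl on this aromatic carbon brings no lower number. That floor alone shows no change beyond the scatter. On these data alone, the true size of the step stays unknown, and so does the effect of an amine or a carboxylic acid on that aromatic carbon.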